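Para-substituent swap on the aminophenyl arm of compound 1

A few compounds are considered here, and "the series" means these few. Any claim that something is new, unique, unknown or untested is made for them only; others in the source may bear on it.

Compound 1 `COc1cc2c(cc1OC)C(c1ccc(N)cc1)=NN=C(S)C2` is the reference point of this set. In a functional assay on the whole organism with Mus musculus as the target (on this read-out lower numbers stand for an effect already at smaller amounts and higher numbers for an effect only at larger amounts of compound), compound 1 gives 3.3 umol/kg, the lowest of the three numbers recorded. Compound 2 `COc1cc2c(cc1OC)C(c1ccccc1)=NNC(=O)C2` gives 31.8 umol/kg and compound 3 `COc1cc2c(cc1OC)C(c1ccc(Br)cc1)=NNC(=O)C2` gives 82.5 umol/kg; both carry a core that differs from that of compound 1 in the ring bearing the phenyl group, so neither stands in a single-change relation to compound 1.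

The compound in question is compound 4 `COc1cc2c(cc1OC)C(c1ccc(Cl)cc1)=NN=C(S)C2`, which differs from compound 1 as follows: chloro in place of amino on an aromatic carbon. Among the measured compounds shown here, no measured pair shows this exact change. For the measured compounds named here, the one single-point step available is a 2.6-fold higher number from compound 2 to compound 3 (0.41 log units; beyond the scatter), a halogen entering at the same position of the phenyl ring, on the other core. It offers only an indirect reading: a halogen entering para to a large group moved the number up modestly. Amino leaving and chloro entering is a larger change than hydrogen giving way to bromo, and on a different core, so the expectation is loosely held.

The step for this assay is expected to be a 2.7-fold higher number from compound 1 to compound 4 (0.44 log units; beyond the scatter), an increase beyond the scatter but well short of the gap between compound 1 and compound 2. Compound 4 is estimated at 9 umol/kg, within a range of 3 umol/kg to 27 umol/kg.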

Compound 4, dose for half-maximal effect: 55 umol/kg
Compound 4: the middle estimate sits 6.1-fold (0.79 log units) below what was measured; the whole stated range lies below it.
By their numbers in this assay, from the lowest: compound 1; then compounds 2, 4 and 3 (each within the scatter of the next, the first and the last beyond it).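

In this assay, the aromatic carbon carrying the amino group proves sensitive on the core of compound 1: chloro in place of amino gives a large step (a 17-fold higher number from compound 1 to compound 4 (1.22 log units; beyond the scatter)). Among the compounds shown here, the low number of compound 1 therefore does not survive the loss of the amino group on this core, which the earlier compounds could not show, since none of them carries a single change from compound 1. The halogen step on the other core is only modest (a 2.6-fold higher number from compound 2 to compound 3 (0.41 log units; beyond the scatter)), so that step does not carry over in size from one core to the other, although the two changes also differ in the groups involved, and nothing at hand accounts for the size of the new step.

Going by these compounds, whether the low number belongs to the amino group alone, or would also hold for a hydroxy, methoxy or dimethylamino group at the same place, stays open. Also open, on these data alone, are where the unsubstituted phenyl sits on the core of compound 1 and whether an amino group would lower the number on the core of compound 2.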